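The compounds below may be only part of what the source reports. "The series", "measured", "known", "first", "only" and "open" are said of these compounds alone.

In a functional assay on PC-3 cells (Homo sapiens) for antiproliferative activity (on this read-out higher numbers stand for weaker inhibition of growth and lower numbers for stronger inhibition of growth), compound 3 `Cc1cc(C)c2c(O)cc(-c3cccc4ccccc34)nc2n1` stands highest of the three measured, at 759 nM, ahead of compound 1 `Cc1cccc(-c2cc(O)c3ccc(C)nc3n2)c1` at 138 nM and compound 2 `Cc1ccnc2nc(-c3cccc4ccccc34)cc(O)c12` at 20 nM. Compound 4 `Cc1ccc2c(O)cc(-c3cccc4ccccc34)nc2n1` differs from compound 3 by hydrogen in place of methyl on an aromatic carbon, opposite the ring nitrogen. Among the measured compounds shown here, the one measured step that bears on this is a 38-fold higher number from compound 2 to compound 3 (1.58 log units; beyond the scatter), a large rise on adding the other methyl of compound 3, so it is only an analogy. Compound 4 keeps that other methyl, as does compound 1 at 138 nM. A clear fall beyond the scatter is expected in this assay, with an estimated size of a 6.9-fold lower number from compound 3 to compound 4 (0.84 log units; beyond the scatter). For compound 4 the estimate is 110 nM, with an expected range of 28 nM to 430 nM.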

Compound 4, concentration for 50% growth inhibition: 30.2 nM
Compound 4: middle estimate off by 3.6-fold (0.56 log units), on the high side; the measured number falls inside the stated range.
By their numbers in this assay, from the lowest: compounds 2 and 4 (each within the scatter of the next); then compound 1; then compound 3.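

In this assay, hydrogen in place of methyl on the aromatic carbon opposite the ring nitrogen gives a 25-fold lower number from compound 3 to compound 4 (1.40 log units; beyond the scatter) and shows that this position alone carries a large step. Set beside a 38-fold higher number from compound 2 to compound 3 (1.58 log units; beyond the scatter) on the other methyl, it ties the high number to compound 3 with both methyls rather than to the methyl at this position alone. No measurement on hand accounts for the size of this step.

Going by these compounds, whether ethyl, methoxy, chlorine or an amine at this position would behave like hydrogen or like methyl stays open. Also open, on these data alone, is whether the step holds with the aryl group of compound 1.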